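The source may report more compounds than this note shows. Statements on the series, on what has been measured and on what is new or still open speak of the compounds shown alone.

Compound 1 `Cc1ccc2c(=O)c(CSC(=S)N3CCCCC3)coc2c1` is measured in a functional assay on HEp-2 cells (Homo sapiens) for antiproliferative activity, read by MTT assay, with a stated time of 72 h (on this read-out higher numbers stand for weaker inhibition and lower numbers for stronger inhibition), where compound 1 gives 900 nM. Among the three numbers known so far that is the second highest. The nearest is compound 2 `O=c1c(CSC(=S)N2CCCCC2)coc2cc(Cl)ccc12`, which in this assay gives 280 nM; the step of a 3.2-fold lower number from compound 1 to compound 2 (0.51 log units; beyond the scatter) comes from a chloro in place of methyl on an aromatic carbon swap confined to the aromatic ring. Within the data shown here, the furthest is compound 3 `O=c1c(SC(=S)N2CCCCC2)coc2ccc(Cl)cc12`, which in this assay gives 12200 nM, a markedly higher number than compound 1, but the two differ in more than one place, so no single-point step links them.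

Compound 4 `Cc1ccc2c(=O)c(CSC(=S)N(C(C)C)C(C)C)coc2c1` differs from compound 1 by diisopropylamino in place of piperidin-1-yl on a thiocarbonyl carbon. Among the measured compounds shown here, none of the measured steps touches the amine on the thiocarbonyl carbon: the one measured step, from compound 1 to compound 2, changes only the aromatic ring. There is therefore no measured guide for this change. For compound 4 the expected step in this assay is no change at the digits printed from compound 1 to compound 4 (within the scatter), not beyond the scatter. Compound 4 is estimated at 900 nM, within a range from 300 nM to 2700 nM.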

Compound 4, half-maximal inhibitory concentration: 700 nM
For compound 4 the middle estimate is 1.3-fold (0.11 log units) above the measured one; measured number inside the range.
By their numbers in this assay, from the lowest: compound 2; then compounds 4 and 1 (each within the scatter of the next); then compound 3.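

In this assay, putting diisopropylamino in place of piperidin-1-yl on the thiocarbonyl carbon gives a 1.3-fold lower number from compound 1 to compound 4 (0.11 log units; within the scatter). Among these compounds, this is the first measured change at this place, and it shows that, on the core of compound 1, the ring of piperidin-1-yl can give way to an open amine carrying two branched chains while the two compounds stay indistinguishable on this read-out. Nothing measured here explains why these two amines read alike.

As far as these compounds go, whether the same holds for other amines at this place remains open, for example a morpholine ring, a small dimethylamino group or an amine that keeps a hydrogen on its nitrogen. Also open, from the compounds shown here alone, is whether diisopropylamino would read the same alongside the chloro group of compound 2.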